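Trifluoromethyl for methoxy on the aryl of compound 2

This account rests on a few compounds, and the source may have more. Where it says the series, first, only, none or still open, it means among the compounds named here.

Measured compounds:
compound 1 `COc1ccc(-c2nc(C(=O)/C=C\Nc3ccc(Cl)cc3)c3ccccn23)cc1`: 37300 nM
compound 2 `COc1ccc(N/C=C\C(=O)c2nc(-c3ccc(OC)cc3)n3ccccc23)cc1`: 15400 nM

In a functional assay on BT-474 cells (Homo sapiens) for cytotoxicity, read by MTT assay, with a stated time of 48 h (on this read-out higher numbers stand for weaker inhibition and lower numbers for stronger inhibition), compound 1 gives 37300 nM and compound 2 gives 15400 nM. Going by the values given here, compound 2 therefore holds the lowest of the two numbers, and its only neighbour is compound 1, separated by a 2.4-fold lower number from compound 1 to compound 2 (0.38 log units; beyond the scatter), a change of methoxy in place of chloro on an aromatic carbon of the anilino ring.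

Compound 3 `COc1ccc(N/C=C\C(=O)c2nc(-c3ccc(C(F)(F)F)cc3)n3ccccc23)cc1` differs from compound 2 by trifluoromethyl in place of methoxy on an aromatic carbon. This change sits on the other aryl ring, the one attached to the shared core, not on the ring altered in the step from compound 1 to compound 2. Among the compounds with values here, no measured step touches that ring, so the single step that exists, a 2.4-fold lower number from compound 1 to compound 2 (0.38 log units; beyond the scatter), bears on it only as a sign that substituent swaps on these aryl rings have so far moved this assay modestly. On that basis compound 3 is expected to show no step beyond the scatter, a 1.0-fold lower number from compound 2 to compound 3 (0.01 log units; within the scatter). The estimate for compound 3 in this assay is 15000 nM, with a range from 4000 nM to 55000 nM.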

Compound 3, half-maximal inhibitory concentration: > 30000 nM
Compound 3: only a limit was reported (the forecaster's own chance of this, stated with the estimate: 15%); at least 2.0-fold (0.30 log units) between middle value and limit.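

Going by these compounds alone, the swap from 4-methoxyphenyl to 4-(trifluoromethyl)phenyl gives the first reading on the aryl ring attached to the shared core, whereas the earlier step had touched only the anilino ring: in this assay, the change gives an at least 1.9-fold higher number from compound 2 to compound 3 (0.28 log units; that floor lies within the scatter). On these data alone, compound 3 is reported only as a limit, > 30000 nM, so the step is a floor and the true size of the change at this position remains unknown. The floor lies within the scatter, so it does not by itself separate the two compounds, and the result shows only that this position has not yet given a second number to set beside that of compound 2, with the reading for trifluoromethyl resting on: the limit of > 30000 nM in this assay, at which 1 of the 3 values shown sits.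

The compounds shown leave open how far compound 3 actually lies from compound 2, and whether an amine, a carboxylic acid or a longer chain in this same place would return a number within the range of this assay. They also leave open whether trifluoromethyl would give a comparable result on the anilino ring, where only chloro and methoxy appear.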